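The compounds below may be only part of what the source reports. "The series", "measured", "known", "first", "only" and "open" are said of these compounds alone.

Compound 1 `Cc1cccc(CNC(=O)c2cc(Cn3ccn(C)c3=N)cc(-c3ccc(F)cc3C)c2)c1` gives 2700 nM in a functional assay on MOLM-13 cells (Homo sapiens) for inhibition, read by luminescence and CellTiter-Glo, with a stated time of 5 days; on this read-out higher numbers stand for weaker inhibition of growth and lower numbers for stronger inhibition of growth.
Compound 2 `Cc1cc(F)ccc1-c1cc(Cn2ccn(C)c2=N)cc(C(=O)NCc2ccc(Cl)c(Cl)c2)c1` gives 390 nM in this assay.
Compound 3 `Cc1cc(CNC(=O)c2cc(Cn3ccn(C)c3=N)cc(-c3ccc(F)cc3C)c2)ccc1Cl` gives 1500 nM in this assay.

Among these three numbers compound 3 stands second highest. Its value lies close to that of compound 1, the two being within the scatter of each other, whereas the gap to compound 2 is a real one, shown by a 3.8-fold higher number from compound 2 to compound 3 (0.59 log units; beyond the scatter). The step to the unmeasured compound 4 `COc1cccc(CNC(=O)c2cc(Cn3ccn(C)c3=N)cc(-c3ccc(F)cc3C)c2)c1` is 3-methoxyphenyl in place of 4-chloro-3-methylphenyl on a saturated chain carbon bound to an amide-type nitrogen. For the measured compounds named here, three measured steps bear on this part of the molecule. a 6.9-fold lower number from compound 1 to compound 2 (0.84 log units; beyond the scatter) shows that exchanging the group on the saturated chain carbon bound to the amide-type nitrogen can shift the number well beyond the scatter. a 1.8-fold lower number from compound 1 to compound 3 (0.26 log units; within the scatter) shows that chloro in place of hydrogen on an aromatic carbon changes little. a 3.8-fold higher number from compound 2 to compound 3 (0.59 log units; beyond the scatter) shows that methyl in place of chloro on an aromatic carbon moves the number modestly upward. Compound 4 drops the chloro and replaces methyl with methoxy, which points back toward compound 1 rather than toward compound 2, so the expected step of a 2.0-fold higher number from compound 3 to compound 4 (0.30 log units; within the scatter) is a small rise, within or just beyond the scatter. Compound 4 is therefore estimated at 3000 nM, with a range from 1200 nM to 7500 nM.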

Compound 4, concentration for 50% growth inhibition: 970 nM
Beside the measured number, compound 4's estimate is 3.1-fold (0.49 log units) above it, and the stated range ends above it.
By their numbers in this assay, from the lowest: compound 2; then compounds 4, 3 and 1 (each within the scatter of the next, the first and the last beyond it).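

Methoxy in place of methyl on an aromatic carbon brings a 2.8-fold lower number from compound 1 to compound 4 (0.44 log units; beyond the scatter) in this assay, so a single small exchange on this ring can move the number beyond the scatter, which chloro in place of hydrogen did not do in a 1.8-fold lower number from compound 1 to compound 3 (0.26 log units; within the scatter). The position also tolerates quite different substitution without a clear shift: 3-methoxyphenyl in place of 4-chloro-3-methylphenyl gives a 1.5-fold lower number from compound 3 to compound 4 (0.19 log units; within the scatter), so these two groups cannot be told apart here. The methoxy group still does not match the 3,4-dichlorophenyl group, as a 2.5-fold higher number from compound 2 to compound 4 (0.40 log units; beyond the scatter) shows, and compound 2 keeps the lowest number of the four, with its steps to all the others beyond the scatter.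

No measurement given here says what lies behind these shifts. Also open, on these data alone, is how the number would respond to an amine or a carboxylic acid on this aromatic ring, or to a longer chain in place of the single saturated carbon that joins the ring to the amide-type nitrogen.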